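Removing the hydroxy: from compound 2 to compound 3

A few compounds are considered here, and "the series" means these few. Any claim that something is new, unique, unknown or untested is made for them only; others in the source may bear on it.

Measured compounds:
compound 1 `CCCCCSc1nc(N)c2nc(O)n(Cc3ccccc3)c2n1`, 10 uM
compound 2 `Nc1nc(O)nc2c1nc(O)n2Cc1ccccc1`, 0.1 uM

Compound 2 gives the lowest number of the two in a functional assay (spleen, spleen) for activation, with Mus musculus as the target; a lower number here means that less compound is needed, a higher number that more compound is needed for the effect; compound 1 needs a much higher concentration, as a 100-fold lower number from compound 1 to compound 2 (2.00 log units; beyond the scatter) shows. Compound 3 `Nc1ncnc2c1nc(O)n2Cc1ccccc1` differs from compound 2 by hydrogen in place of hydroxy on an aromatic carbon. Going by the values given here, only that one step touches this position, and it was large, so the position clearly matters. With the hydroxy gone, a moderately higher number is expected for compound 3, a 10-fold higher number from compound 2 to compound 3 (1.00 log units; beyond the scatter). The estimate for compound 3 is 1 uM, within 0.1 uM to 10 uM.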

Compound 3, minimum effective concentration: 10 uM
Beside the measured number, compound 3's estimate is 10-fold (1.00 log units) below it; measured number inside the range.
By their numbers in this assay, from the lowest: compound 2; then compounds 1 and 3 (each within the scatter of the next).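

In this assay, the step of a 100-fold higher number from compound 2 to compound 3 (2.00 log units; beyond the scatter) shows that compound 2 owes its low number to the hydroxy itself, not merely to the loss of pentylsulfanyl. Hydrogen in place of pentylsulfanyl gives no change at the digits printed from compound 1 to compound 3 (within the scatter), so these two groups cannot be told apart at this aromatic carbon, and only hydroxy stands out. Nothing at hand explains this result. Going by these compounds, it remains open whether an amine or a methoxy group on this carbon would keep the low number of compound 2.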